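Methyl urea in place of methyl carbamate on an agonist

This account rests on a few compounds, and the source may have more. Where it says the series, first, only, none or still open, it means among the compounds named here.

Three compounds share one core. Compound 1 `CCCCCCCCN1C(=O)[C@H](Cc2ccc(-c3cc(OC)c(OC)c(OC)c3)cc2)N(C)C(=O)[C@@H]1C` gives 32 nM in a functional assay on cells for agonist activity at follicle-stimulating hormone receptor (Homo sapiens), read by cAMP accumulation; on this read-out higher numbers stand for an effect only at larger amounts of compound and lower numbers for an effect already at smaller amounts. Compound 2 `CCCCCCN1C(=O)[C@H](Cc2ccc(-c3cccc(CN(CCCC)C(=O)OC)c3)cc2)N(C)C(=O)[C@@H]1C` gives 48 nM; 59 nM (2 entries) in this assay, as the repeated entries show (the several entries of compound 2 in this assay, 48 nM; 59 nM (2 entries)). Compound 3 `CCCCCCCCN1C(=O)[C@H](Cc2ccc(-c3cccc(CN(CCCC)C(=O)OC)c3)cc2)N(C)C(=O)[C@@H]1C` gives 31 nM; among the two single numbers it is the lowest, and compound 1 sits within the scatter of it. Compound 4 `CCCCCCCCN1C(=O)[C@H](Cc2ccc(-c3cccc(CN(CCCC)C(=O)NC)c3)cc2)N(C)C(=O)[C@@H]1C` is not yet measured. It differs from compound 3 only in methylamino in place of methoxy on a carbonyl carbon. Going by the values given here, no measured pair shows this change, so no size can be read from the data; the writer expects a step no larger than the scatter, in no set direction. For compound 4 the estimate in this assay is 40 nM, between 12 nM and 130 nM, which means a step of a 1.3-fold higher number from compound 3 to compound 4 (0.11 log units; within the scatter).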

Compound 4, half-maximal effective concentration: 7.9 nM
Compound 4: middle estimate off by 5.1-fold (0.70 log units), on the high side; the whole stated range lies above it.
By their numbers in this assay, from the lowest: compound 4; then compounds 3 and 1 (each within the scatter of the next).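

In this assay, methylamino in place of methoxy on a carbonyl carbon, whose other neighbour is an amide-type nitrogen, gives a 3.9-fold lower number from compound 3 to compound 4 (0.59 log units; beyond the scatter). Going by these compounds alone, this is the first measured change at this place, and it shows that the position responds to this exchange by more than the usual scatter. The compounds shown give no measured basis for explaining the step.

As far as these compounds go, it remains open whether dimethylamino or ethylamino on the same carbonyl carbon would keep this gain. From the compounds shown here alone, it is also open whether the same exchange would carry over to compound 2.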